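The source may hold more compounds than are shown below. What is called first, only, known or untested is meant among the compounds shown, and "the series" means these compounds.

Compound 1 `COc1ccccc1/C=C(/SCc1ccc(F)cc1)C(=O)c1ccc(Br)cc1` and compound 2 `COc1ccccc1/C=C(/Sc1ccc(C)cc1)C(=O)c1ccc(Br)cc1` share one core and differ in a single group: 4-methylphenyl in place of 4-fluorobenzyl on a sulfur. In a functional assay on DU-145 cells (Homo sapiens) for inhibition, read by trypan blue exclusion, with a stated time of 96 h (on this read-out higher numbers stand for weaker inhibition of growth and lower numbers for stronger inhibition of growth), compound 1 gives 10000 nM, and compound 2 gives 9000 nM, so that change made a 1.1-fold lower number from compound 1 to compound 2 (0.05 log units; within the scatter). Compound 3 `COc1cc(OC)c(/C=C(/SCc2ccc(F)cc2)C(=O)c2ccc(Br)cc2)c(OC)c1` carries a different core; how its core differs from that of compound 1 is not broken down here. In this assay compound 3 gives 1000 nM. Compound 4 `COc1cc(OC)c(/C=C(/Sc2ccc(C)cc2)C(=O)c2ccc(Br)cc2)c(OC)c1` stands to compound 3 exactly as compound 2 stands to compound 1: 4-methylphenyl in place of 4-fluorobenzyl on a sulfur, the same change at the same place on the sulfur. Because the earlier step of a 1.1-fold lower number from compound 1 to compound 2 (0.05 log units; within the scatter) stayed within the scatter, a similarly small step is expected on the new core, a 1.1-fold lower number from compound 3 to compound 4 (0.05 log units; within the scatter). Compound 4 is therefore estimated to give about 900 nM in this assay, with a likely range from 400 nM to 2500 nM.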

Compound 4, concentration for 50% growth inhibition: > 100000 nM
Compound 4: no number, only a limit; the forecaster's own chance of this, stated with the estimate: 5%; at least 110-fold (2.04 log units) between middle value and limit.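

In this assay compound 4 gives > 100000 nM, which is a limit of the assay and not a number. Putting 4-methylphenyl in place of 4-fluorobenzyl on the sulfur gave an at least 100-fold higher number from compound 3 to compound 4 (2.00 log units; beyond the scatter), so the change did not carry over unaltered, and the two steps differ: the same change on two cores in this assay, a 1.1-fold lower number (0.05 log units; within the scatter) from compound 1 to compound 2 and an at least 100-fold higher number (2.00 log units; beyond the scatter) from compound 3 to compound 4, at least 110-fold (2.04 log units) apart, beyond the scatter of two such steps. This shows that the effect of this change depends on the core in these two pairs, but it does not show why, and two pairs give no rule for other cores.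

The compounds shown leave open which part of the change matters on the core of compound 3; a 4-fluorophenyl or a plain benzyl on the sulfur would help separate the parts. They also leave open how an amine or a carboxylic acid on that group would behave on either core.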